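The source may hold more compounds than are shown below. What is called first, only, known or untested is meant among the compounds shown, and "the series" means these compounds.

Compound 2 `Cc1ccc(NC2=C(C(=O)c3ccccc3)C(c3ccc(Br)cc3)N(CCCn3ccnc3)C2=O)cc1` and compound 1 `O=C(C1=C(Nc2ccccc2)C(=O)N(CCCn2ccnc2)C1c1ccc(Br)cc1)c1ccccc1` share one core and differ only by a methyl on an aromatic carbon. In a functional assay on SAOS-2 cells (Homo sapiens) for antiproliferative activity, read by MTT assay, with a stated time of 72 h (on this read-out lower numbers stand for stronger inhibition and higher numbers for weaker inhibition), compound 1 gives 24400 nM, and compound 2 gives 31900 nM. Among the compounds with values here, the one measured step, a 1.3-fold higher number from compound 1 to compound 2 (0.12 log units; within the scatter), is within the scatter, so the two numbers cannot be told apart; compound 2 stands beside compound 1 rather than apart from it.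

Compound 3 `O=C(C1=C(Nc2ccc(Cl)cc2)C(=O)N(CCCn2ccnc2)C1c1ccc(Br)cc1)c1ccccc1` is the next step from compound 2: chloro in place of methyl on an aromatic carbon. Within the data shown here, no measured step shows a chloro entering in this place, so the only guide is the indifference of this assay to the methyl in the same place, seen in a 1.3-fold higher number from compound 1 to compound 2 (0.12 log units; within the scatter). Replacing that methyl with a chloro, a group of the same size in heavy atoms, is therefore expected to leave the number close to where compound 2 sits, with no step beyond the scatter in either direction; the expected step is a 1.1-fold lower number from compound 2 to compound 3 (0.06 log units; within the scatter). Compound 3 is estimated to give 28000 nM in this assay, within a range from 12000 nM to 65000 nM.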

Compound 3, half-maximal inhibitory concentration: 24800 nM
For compound 3 the middle estimate is 1.1-fold (0.05 log units) above the measured one; low and high end bracket the measured number.
By their numbers in this assay, from the lowest: compounds 1, 3 and 2 (each within the scatter of the next).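

Chloro in place of methyl on this aromatic carbon gives a 1.3-fold lower number from compound 2 to compound 3 (0.11 log units; within the scatter) and chloro in place of hydrogen gives a 1.0-fold higher number from compound 1 to compound 3 (0.01 log units; within the scatter) in this assay so both steps lie within the scatter. Where the earlier compounds showed only that a methyl on this carbon could not be told apart from hydrogen, chloro now joins them, and hydrogen, methyl and chloro at this one place cannot be separated by their numbers across compounds 1, 2 and 3. Nothing available bears on what lies behind this result.

The compounds shown leave open whether an amine, a carboxylic acid or a longer chain on this same aromatic carbon would also stay within the scatter of these three numbers, since the groups seen here carry no more than one heavy atom. They also leave open whether a methyl or chloro on another carbon of this aromatic ring would behave in the same way, and what a change elsewhere in the shared core would do.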